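Swapping a pyrrole for methoxyphenyl on an acrylamide

This account rests on a few compounds, and the source may have more. Where it says the series, first, only, none or still open, it means among the compounds named here.

Of the compounds shown here, three have been measured in a functional assay on A-431 cells (Homo sapiens) for inhibition, read by MTT assay, with a stated time of 72 h; a lower number here means a stronger inhibitor of growth, a higher number a weaker inhibitor of growth. Compound 1 `N#C/C(=C\c1ccc(Cl)cc1)C(=O)c1ccc[nH]1` gives 52000 nM in this assay. Compound 2 `N#C/C(=C\c1c[nH]c2ccccc12)C(=O)c1c[nH]c2ccccc12` gives 7600 nM in this assay. Compound 3 `N#C/C(=C\c1ccc[nH]1)C(=O)NCc1ccc(Cl)c(Cl)c1` is the only one that carries an amide rather than a ketone, and in this assay compound 3 reaches only a limit of the assay, > 50000 nM. That limit is the point at which one of the three values sits, as the limit of > 50000 nM in this assay, at which 1 of the 3 values shown sits, shows, so compound 3 stands at the weak end of what was seen, with no exact number behind it.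

Compound 4 `COc1ccc(/C=C(\C#N)C(=O)NCc2ccc(Cl)c(Cl)c2)cc1` keeps the amide of compound 3 and changes one part: 4-methoxyphenyl in place of 1H-pyrrol-2-yl on a double-bonded chain carbon bound to a double-bonded chain carbon. Within the data shown here, no pair of measured compounds differs in just this place, so nothing measured shows what such a swap does here. The expectation for this assay is a step from compound 3 to compound 4 of a step that the limit leaves unreadable from compound 3 to compound 4, no more than the scatter of repeated measurements. Compound 4 is therefore estimated at 55000 nM, expected to lie between 15000 nM and 200000 nM.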

Compound 4, concentration for 50% growth inhibition: 90000 nM
Estimate against measurement, compound 4: 1.6-fold (0.21 log units) below; low and high end bracket the measured number.
By their numbers in this assay, from the lowest: compound 2; then compounds 1 and 4 (each within the scatter of the next).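

In this assay compound 3 gives > 50000 nM, which is a limit and not a number. No step from compound 3 to compound 4 can therefore be read, and the reason is this: the limit of > 50000 nM in this assay, at which 1 of the 4 values shown sits. The compounds shown leave open how far 4-methoxyphenyl in place of 1H-pyrrol-2-yl shifts growth inhibition.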